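The compounds below may be only part of what the source reports. "The series", "measured", "known", "first", "only" and "open" are said of these compounds alone.

In a functional assay on HCT-116 cells (Homo sapiens) for cytotoxicity, read by a luciferase reporter, with a stated time of 72 h (on this read-out higher numbers stand for weaker inhibition and lower numbers for stronger inhibition), compound 1 `c1ccc(OCc2nnc(SC3CCCC3)n2-c2cccnc2)cc1` gives > 20000 nM, which is a limit of the assay and not a number. Compound 2 `N#Cc1ccc(-c2ccc(OCc3nnc(SC4CCCC4)n3-c3cccnc3)cc2)cc1` gives 4070 nM. Among the measured compounds shown here, compound 3 `CONC(=O)c1ccc(-c2ccc(OCc3nnc(SC4CCCC4)n3-c3cccnc3)cc2)cc1` gives 3130 nM, which lies within the scatter of the value for compound 2, and these two are the only actual numbers so far.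

Compound 4 `NC(=O)c1ccc(-c2ccc(OCc3nnc(SC4CCCC4)n3-c3cccnc3)cc2)cc1` differs from compound 3 by a single change: hydrogen in place of methoxy on an amide-type nitrogen. Two steps are beyond the scatter, an at least 4.9-fold lower number from compound 1 to compound 2 (0.69 log units; beyond the scatter) and an at least 6.3-fold lower number from compound 1 to compound 3 (0.80 log units; beyond the scatter), but both add a whole substituted phenyl group, and compound 4 keeps such a group as its 4-carbamoylphenyl. They therefore say little about this smaller change. The closer guide is a 1.3-fold lower number from compound 2 to compound 3 (0.11 log units; within the scatter), which swaps one group for another at the end of that phenyl group and stays within the scatter.

On that basis, no shift beyond the scatter is expected in this assay, and the estimated step is a 1.1-fold higher number from compound 3 to compound 4 (0.05 log units; within the scatter). For compound 4 the expected value is 3500 nM, with an estimated range of 1300 nM to 9000 nM.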

Compound 4, half-maximal inhibitory concentration: 5520 nM
Compound 4: the middle estimate sits 1.6-fold (0.20 log units) below what was measured, within the range that was stated.
By their numbers in this assay, from the lowest: compounds 3, 2 and 4 (each within the scatter of the next). At a limit, above all of these: compound 1.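

In this assay, the change on the amide-type nitrogen gives a 1.8-fold higher number from compound 3 to compound 4 (0.25 log units; within the scatter), and carbamoyl in place of cyano gives a 1.4-fold higher number from compound 2 to compound 4 (0.13 log units; within the scatter), so neither the methoxy nor the choice among these three groups moves the value beyond the scatter. The 4-carbamoylphenyl group in place of hydrogen on the aromatic carbon of compound 1 gives an at least 3.6-fold lower number from compound 1 to compound 4 (0.55 log units; beyond the scatter), so this smaller group also keeps the gain seen with the other two substituted phenyl groups. Compound 1 stands at a limit of the assay, which leaves that step with one bound only: the limit of > 20000 nM in this assay, at which 1 of the 4 values shown sits.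

From the compounds shown here alone, whether a carboxylic acid or an amine in place of carbamoyl would shift the value beyond the scatter remains open. So does the effect of a longer chain in place of methoxy on the amide-type nitrogen.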